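Pyrazole Attachment Swap Across Two Urea Cores

The source may report more compounds than this note shows. Statements on the series, on what has been measured and on what is new or still open speak of the compounds shown alone.

Compound 1 `CSc1cc(C)nc(SC)c1NC(=O)N(Cc1ccccc1)Cc1cccc(-c2ccn(C)n2)c1` and compound 2 `CSc1cc(C)nc(SC)c1NC(=O)N(Cc1ccccc1)Cc1cccc(-c2ccnn2C)c1` share one core, while compound 3 `Cc1cc(C)c(NC(=O)N(Cc2ccc(-c3ccn(C)n3)cc2)C2CCCCCC2)c(C)c1` carries another; the difference between the two cores is not broken down here. In a functional assay on a cell-free system (plasma) with sterol O-acyltransferase, Soat (Rattus norvegicus) as the target (a higher number here means that more compound is needed for the effect, a lower number that less compound is needed), compound 1 gives < 1 mg/kg, which is a limit of the assay rather than a number. Compound 2 likewise gives < 1 mg/kg, also a limit. Compound 3 gives < 1 mg/kg, again a limit. From compound 1 to compound 2 the change is 1-methyl-1H-pyrazol-5-yl in place of 1-methyl-1H-pyrazol-3-yl on an aromatic carbon, and the step is a step that the two limits leave unreadable from compound 1 to compound 2. Compound 4 `Cc1cc(C)c(NC(=O)N(Cc2ccc(-c3ccnn3C)cc2)C2CCCCCC2)c(C)c1` arises from compound 3 by the same kind of change, (1-methyl-1H-pyrazol-5-yl in place of 1-methyl-1H-pyrazol-3-yl on an aromatic carbon); the surroundings differ in that the group sits meta to a large group in the first pair and para to a large group in the second. Because the limit of < 1 mg/kg in this assay, at which 3 of the 3 values shown sit, places every measured value at the limit, the expected step is a step that the limit leaves unreadable from compound 3 to compound 4. Compound 4 is estimated to give 0.5 mg/kg.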

Compound 4, dose for half-maximal effect: < 1 mg/kg
Compound 4: only a limit was reported (the forecaster's own chance of this, stated with the estimate: 80%); the middle value is on the limit's open side.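

Compound 4 and compound 3 differ only in how the pyrazole is attached, yet no step can be read between them, because the result sits at a limit: the limit of < 1 mg/kg in this assay, at which 4 of the 4 values shown sit.

As far as these compounds go, whether this swap changes the dose needed in this assay stays open for both cores.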